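This account rests on a few compounds, and the source may have more. Where it says the series, first, only, none or still open, it means among the compounds named here.

Of the compounds shown here, three built on one shared core have been measured in an assay on isolated protein for inhibition of glutathione S-transferase Mu 2 (Homo sapiens), with a stated time of 10 min; on this read-out lower numbers stand for stronger inhibition and higher numbers for weaker inhibition. Compound 1 `Cc1ccccc1NC(=O)CCC(=O)OCCCCCCSc1ccc([N+](=O)[O-])c2nonc12` gives 440 nM. Compound 2 `O=C(CCC(=O)OCCCCCCSc1ccc([N+](=O)[O-])c2nonc12)Nc1cccc(Cl)c1` gives 1100 nM. Compound 3 `O=C(CCC(=O)OCCCCCCSc1ccc([N+](=O)[O-])c2nonc12)Nc1ccc(F)cc1` gives 320 nM, the lowest of the three numbers, although its gap to compound 1 lies within the scatter while its gap to compound 2 lies beyond it: a 1.4-fold lower number from compound 1 to compound 3 (0.14 log units; within the scatter) and a 3.4-fold lower number from compound 2 to compound 3 (0.54 log units; beyond the scatter). Compound 4 `Cc1ccc(NC(=O)CCC(=O)OCCCCCCSc2ccc([N+](=O)[O-])c3nonc23)cc1` differs from compound 3 in one place: methyl in place of fluoro on an aromatic carbon. The steps measured so far each exchange the whole aryl group on the amide nitrogen, and none of them swaps fluoro for methyl on the same ring position. The step of a 2.5-fold higher number from compound 1 to compound 2 (0.40 log units; beyond the scatter) was modest, a 3.4-fold lower number from compound 2 to compound 3 (0.54 log units; beyond the scatter) was modest in the other direction, and a 1.4-fold lower number from compound 1 to compound 3 (0.14 log units; within the scatter) stayed within the scatter. On this basis the step of a 1.2-fold higher number from compound 3 to compound 4 (0.07 log units; within the scatter) is expected to stay within the scatter, with no clear direction. Compound 4 is therefore estimated at 380 nM in this assay, within an expected range of 160 nM to 900 nM.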

Compound 4, half-maximal inhibitory concentration: 390 nM
For compound 4 the middle estimate is 1.0-fold (0.01 log units) below the measured one; low and high end bracket the measured number.
By their numbers in this assay, from the lowest: compounds 3, 4 and 1 (each within the scatter of the next); then compound 2.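

In this assay, going by these compounds alone, methyl in place of fluoro on an aromatic carbon para to a large group gives a 1.2-fold higher number from compound 3 to compound 4 (0.09 log units; within the scatter), so at this position the two groups cannot be told apart, a direct exchange that the earlier steps, each replacing the whole aryl group, did not offer. The 4-methylphenyl group also reads level with the 2-methylphenyl group, at a 1.1-fold lower number from compound 1 to compound 4 (0.05 log units; within the scatter), while the 3-chlorophenyl group stays apart, with a 2.8-fold lower number from compound 2 to compound 4 (0.45 log units; beyond the scatter), so that compound 2 is now separated from all three other compounds. Nothing available explains these results.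

The compounds shown leave open how an amine or a carboxylic acid on this same ring carbon would read. They also leave open whether a hydroxyl group there would stay as close to fluoro and methyl as those two stay to each other.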